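Dropping the halogen from the aniline ring of compound 2

A few compounds are considered here, and "the series" means these few. Any claim that something is new, unique, unknown or untested is made for them only; others in the source may bear on it.

Measured so far:
- compound 1, `COc1cc2ncnc(Nc3cccc(Br)c3)c2cc1OCCCCC(=O)Nc1ccc(S(N)(=O)=O)cc1`: 9750 nM
- compound 2, `COc1cc2ncnc(Nc3cccc(Cl)c3)c2cc1OCCCCC(=O)Nc1ccc(S(N)(=O)=O)cc1`: 30400 nM
- compound 3, `COc1cc2ncnc(Nc3ccc(Br)cc3)c2cc1OCCCCC(=O)Nc1ccc(S(N)(=O)=O)cc1`: 6570 nM

These three compounds share one core and differ only in the halogen on the aniline ring and in where it sits. In a functional assay on A-431 cells (Homo sapiens) for antiproliferative activity, read by MTT assay, with a stated time of 72 h (a lower number here means a stronger inhibitor, a higher number a weaker inhibitor), compound 2 gives 30400 nM, the highest number of the three, so it is the weakest inhibitor among them. The step of a 3.1-fold higher number from compound 1 to compound 2 (0.49 log units; beyond the scatter) shows that the chloro compound trails its bromo counterpart, and a 4.6-fold lower number from compound 2 to compound 3 (0.67 log units; beyond the scatter) puts compound 2 further still behind compound 3.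

Compound 4, `COc1cc2ncnc(Nc3ccccc3)c2cc1OCCCCC(=O)Nc1ccc(S(N)(=O)=O)cc1`, is not yet measured. Its change from compound 2 is hydrogen in place of chloro on an aromatic carbon. Among the compounds with values here, no measured step removes a halogen altogether, so the bearing of the known steps is indirect: a 3.1-fold higher number from compound 1 to compound 2 (0.49 log units; beyond the scatter) says that swapping one halogen for another at this position already moves the number beyond the scatter, and a 1.5-fold lower number from compound 1 to compound 3 (0.17 log units; within the scatter) says that moving the bromo around the ring does not. With no halogen left at all, the expectation is a number in the region of compound 2 or somewhat higher, with wide uncertainty. For compound 4 the estimate in this assay is 40000 nM, within 10000 nM to 150000 nM, which would mean a step of a 1.3-fold higher number from compound 2 to compound 4 (0.12 log units; within the scatter).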

Compound 4, half-maximal inhibitory concentration: 25200 nM
Estimate against measurement, compound 4: 1.6-fold (0.20 log units) above; measured number inside the range.
By their numbers in this assay, from the lowest: compounds 3 and 1 (each within the scatter of the next); then compounds 4 and 2 (each within the scatter of the next).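

In this assay, hydrogen in place of chloro gives a result that cannot be told apart from the chloro compound (a 1.2-fold lower number from compound 2 to compound 4 (0.08 log units; within the scatter)), so on this ring carbon the chloro shows no effect that this read-out can separate from the scatter. Bromo behaves differently, since hydrogen in its place raises the number both from the 3-bromophenyl compound (a 2.6-fold higher number from compound 1 to compound 4 (0.41 log units; beyond the scatter)) and from the 4-bromophenyl compound (a 3.8-fold higher number from compound 3 to compound 4 (0.58 log units; beyond the scatter)). Among these four compounds, then, a lower number than that of the plain phenyl goes with bromo at either of the two places shown and not with halogens in general, and compound 2 is the one that goes against any broader rule about halogens.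

Still open, as far as these compounds go, is whether an iodo or fluoro group on this ring would follow bromo or chloro. From the compounds shown here alone, it is equally open where a methyl, a methoxy or an amine at the same carbon would fall relative to the plain phenyl. No measurement offered here explains why bromo and chloro part ways on this ring.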